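Notes on compound 4 in the gastric series

The source may report more compounds than this note shows. Statements on the series, on what has been measured and on what is new or still open speak of the compounds shown alone.

Measured so far: compound 1 `O=c1ccc(-c2ccccc2)nn1CCCCNC(=S)Nc1ccc(Cl)cc1` gives > 100 mg/kg; compound 2 `C/N=C(/NC#N)NCCCCn1nc(N(C)C)ccc1=O` gives > 100 mg/kg; compound 3 `N#CNC(=N)NCCCCCn1nc(-c2ccccc2)ccc1=O` gives > 100 mg/kg.

In a functional assay on the whole organism (stomach) with Rattus norvegicus as the target (a higher number here means that more compound is needed for the effect, a lower number that less compound is needed), the value of compound 3 is a limit of the assay, not a number. The same holds for compound 1 and for compound 2, so that the limit of > 100 mg/kg in this assay, at which 3 of the 3 values shown sit, is the only anchor the series offers. Among the measured compounds shown here, no step between measured compounds is available.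

Compound 4 `C/N=C(/NC#N)NCCCCCCn1nc(-c2ccccc2)ccc1=O` differs from compound 3 by a group of 8 heavy atoms (4 carbon, 4 nitrogen; no ring) in place of a group of 6 heavy atoms (2 carbon, 4 nitrogen; no ring), on a saturated chain carbon, five bonds along the chain from an aromatic nitrogen. In this assay no step beyond the scatter is expected from this change, since compound 2 with its related group also reaches only > 100 mg/kg. Compound 4 is estimated at 150 mg/kg, within 50 mg/kg to 500 mg/kg. The expected step that the limit leaves unreadable from compound 3 to compound 4 is therefore essentially none.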

Compound 4, dose for half-maximal effect: > 100 mg/kg
Compound 4 gave a limit, no number; the forecaster's own chance of this, stated with the estimate: 75%; the middle value does not contradict the limit.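

No step can be read from compound 3 to compound 4 in this assay, as both results are limits: the limit of > 100 mg/kg in this assay, at which 4 of the 4 values shown sit. The compounds shown leave open whether any member of this series gives a true number in this assay.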